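Replacing dimethylamino in compound 3: notes on compound 4

The compounds below may be only part of what the source reports. "The series", "measured", "known", "first", "only" and "open" are said of these compounds alone.

In an ADME assay for permeability, using PAMPA, with a stated time of 4 h, at pH 7.4 (on this read-out lower numbers stand for lower permeability and higher numbers for higher permeability), compound 1 (`NC/C=C\CN(C[C@H]1Cc2ncccc2CN1)[C@H]1CCCc2cccnc21`) reads 68 nm/s and compound 2 (`NC(=O)NC/C=C/CN(C[C@H]1Cc2ncccc2CN1)[C@H]1CCCc2cccnc21`) reads 2 nm/s while compound 3 (`CN(C)CCCCN(C[C@H]1Cc2ncccc2CN1)[C@H]1CCCc2cccnc21`) reads 240 nm/s as the highest of the three numbers. The next step leads to compound 4 (`c1cnc2c(c1)CN[C@@H](CN(CCCCNC1COC1)[C@H]1CCCc3cccnc31)C2`) through a single change ((oxetan-3-yl)amino in place of dimethylamino on a saturated chain carbon, four bonds along the chain from an amine nitrogen) with the rest of the structure kept.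

Among the measured compounds shown here, no measured step makes this exact change. The closest evidence is the modest 3.5-fold higher number from compound 1 to compound 3 (0.55 log units; beyond the scatter) and there the chain differs as well as the amine. For the measured compounds named here, the two large steps, a 34-fold lower number from compound 1 to compound 2 (1.53 log units; beyond the scatter) and a 120-fold higher number from compound 2 to compound 3 (2.08 log units; beyond the scatter) in turn, involve a side chain with no counterpart in the new structure, so they set no useful size here. They show only that this read-out can move far with the side chain. Going by the values given here, the saturated chain stays in place, but the amine is no longer dimethylamino, and the one measured compound with a different chain amine and no further polar-looking addition is compound 1 at 68 nm/s in this comparison.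

A modest move to a lower number is therefore expected in this assay and the estimated step is a 2.2-fold lower number from compound 3 to compound 4 (0.34 log units; beyond the scatter) with wide uncertainty. For compound 4 the estimated value is 110 nm/s with an expected range from 35 nm/s to 320 nm/s on repeat measurement.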

Compound 4, apparent permeability: 300 nm/s
Compound 4: middle estimate off by 2.7-fold (0.44 log units), on the low side; the range from low to high includes it.
By their numbers in this assay, from the lowest: compound 2; then compound 1; then compounds 3 and 4 (each within the scatter of the next).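

At this place on the saturated chain, four bonds along the chain from an amine nitrogen, the read-out in this assay does not separate (oxetan-3-yl)amino from dimethylamino: the exchange, which brings in one four-membered non-aromatic ring with 1 hetero atom and a hydrogen-bond donor, gives a 1.3-fold higher number from compound 3 to compound 4 (0.10 log units; within the scatter). The position therefore tolerates a larger amine substituent in this assay, and the side chain of compound 4 keeps the same standing against the other two compounds as that of compound 3, with a 4.4-fold higher number from compound 1 to compound 4 (0.64 log units; beyond the scatter) and a 150-fold higher number from compound 2 to compound 4 (2.18 log units; beyond the scatter). No measurement at hand bears on why the read-out holds across this exchange.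

The compounds shown leave open whether the same holds for other groups on this chain, such as morpholine, a primary amine or a carboxylic acid, or for (oxetan-3-yl)amino on a shorter or longer chain. They also leave open how (oxetan-3-yl)amino would read on the unsaturated chain of compound 1, which would separate the effect of the chain from that of the amine.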